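Without the amino group: compound 2 to compound 3

The source may hold more compounds than are shown below. What is called first, only, known or untested is meant among the compounds shown, and "the series" means these compounds.

Measured in a functional assay on MCF7 cells (Homo sapiens) for cytotoxicity, read by MTT assay, with a stated time of 24 h; a higher number here means a weaker inhibitor, a lower number a stronger inhibitor:
Compound 1 `Nc1ccc2sc(NC(=S)NC(=O)c3ccccc3)nc2c1`: 38600 nM
Compound 2 `Nc1ccc2sc(NC(=S)NC(=O)c3ccc([N+](=O)[O-])cc3)nc2c1`: 33200 nM

Compound 2 stands level with compound 1 in this assay. For the measured compounds named here, the one measured step, a 1.2-fold lower number from compound 1 to compound 2 (0.07 log units; within the scatter), puts nitro in place of hydrogen on an aromatic carbon. Compound 3 `O=C(NC(=S)Nc1nc2ccccc2s1)c1ccc([N+](=O)[O-])cc1` instead has hydrogen in place of amino on an aromatic carbon. Going by the values given here, no measured step covers this change, so the data give no direct guide to its size. Among the compounds with values here, with only that small step at hand, no change beyond the scatter is expected in this assay, in either direction. The expected step is a 1.1-fold higher number from compound 2 to compound 3 (0.02 log units; within the scatter). For compound 3 the estimate is 35000 nM, with an expected range of 15000 nM to 80000 nM.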

Compound 3, half-maximal inhibitory concentration: 33800 nM
Compound 3: middle estimate off by 1.0-fold (0.02 log units), on the high side; low and high end bracket the measured number.
By their numbers in this assay, from the lowest: compounds 2, 3 and 1 (each within the scatter of the next).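

In this assay, taking the amino group off the aromatic carbon gives a 1.0-fold higher number from compound 2 to compound 3 (0.01 log units; within the scatter), so the number stays level with the nitro group in place. For the compounds shown here, all the earlier compounds carried this amino group, and compound 3 shows that the activity seen here does not depend on it. No measurement bears on why this is so.

On these data alone, it remains open whether another group on this aromatic carbon, such as a methoxy group or a carboxylic acid, would move the number beyond the scatter. As far as these compounds go, it also remains open whether the amino group can be lost equally without the nitro group.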